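The source may hold more compounds than are shown below. What is called first, only, known or untested is meant among the compounds shown, and "the series" means these compounds.

Compound 1 `COc1cc(-c2ccnc3cc(-c4ccc(Cl)cc4)nn23)cc(OC)c1OC`: 3340 nM
Compound 2 `COc1cc(-c2ccnc3cc(-c4ccc(C)c(C)c4)nn23)cc(OC)c1OC`: 261 nM
Compound 3 `COc1cc(-c2ccnc3cc(-c4cn(C)c5ccccc45)nn23)cc(OC)c1OC`: 762 nM

In a functional assay on HCT-116 cells (Homo sapiens) for inhibition, read by CCK-8 assay, with a stated time of 48 h (on this read-out higher numbers stand for weaker inhibition and lower numbers for stronger inhibition), compound 1, at 3340 nM, holds the highest of the three numbers, so it is the weakest inhibitor measured so far in this small set. Compound 4 `CCOC(=O)c1ccc(-c2cc3nccc(-c4cc(OC)c(OC)c(OC)c4)n3n2)cc1` keeps the core of compound 1 and changes one group: ethoxycarbonyl in place of chloro on an aromatic carbon. The ethoxycarbonyl replaces chloro on an aromatic carbon, para to a large group.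

Among the measured compounds shown here, no measured compound carries ethoxycarbonyl, so the evidence is indirect. Two measured steps start from compound 1, and each replaces the whole 4-chlorophenyl: a 13-fold lower number from compound 1 to compound 2 (1.11 log units; beyond the scatter), and a 4.4-fold lower number from compound 1 to compound 3 (0.64 log units; beyond the scatter). Between the two replacements lies a smaller gap, a 2.9-fold higher number from compound 2 to compound 3 (0.47 log units; beyond the scatter). Both steps lower the number, which suggests that compound 1 has room to fall, but neither is a change at the chloro position alone. A lower number is therefore expected for compound 4, though with less confidence than either measured step would imply, and a result within the scatter of compound 1 remains possible. The expected change is a 2.0-fold lower number from compound 1 to compound 4 (0.29 log units; within the scatter). For compound 4 the estimated value in this assay is 1700 nM, with an expected range from 500 nM to 5500 nM.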

Compound 4, half-maximal inhibitory concentration: > 10000 nM
Compound 4: a limit, no number; the forecaster's own chance of this, stated with the estimate: 5%; at least 5.8-fold (0.76 log units) between middle value and limit.
By their numbers in this assay, from the lowest: compound 2; then compound 3; then compound 1. At a limit, above all of these: compound 4.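

In this assay, compound 4 gives only a limit, > 10000 nM, and not a number. With the rest of the structure unchanged, ethoxycarbonyl in place of chloro on an aromatic carbon, para to a large group, gives an at least 2.9-fold higher number from compound 1 to compound 4 (0.47 log units; beyond the scatter); this is the first change shown at the chloro position alone, and it runs against the two earlier steps that replaced the whole 4-chlorophenyl, a 13-fold lower number from compound 1 to compound 2 (1.11 log units; beyond the scatter) and a 4.4-fold lower number from compound 1 to compound 3 (0.64 log units; beyond the scatter). Compound 1 is therefore no longer the top of the series, and a change confined to this one position can move the number upward, with the size of that move bounded on one side only: the limit of > 10000 nM in this assay, at which 1 of the 4 values shown sits.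

Only chloro and ethoxycarbonyl are shown at this position with the rest of the aryl ring unchanged, so it remains open how far compound 4 lies past the limit. Going by these compounds, it also remains open whether a methyl, a carboxylic acid, a primary amide or an amine at the same place would lower the number, leave it level with compound 1 or raise it.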